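A few compounds are considered here, and "the series" means these few. Any claim that something is new, unique, unknown or untested is made for them only; others in the source may bear on it.

Measured so far in this study:
compound 1 `N#Cc1c[nH]c2ncnc(N)c12`: 18000 nM
compound 2 `CCOCn1cc(C(=N)S)c2c(N)ncnc21`: 68000 nM
compound 3 `C=CCn1cc(C#N)c2c(N)ncnc21`: > 100000 nM

All three were tested in a functional assay on KB cells (Homo sapiens) for cytotoxicity; a higher number here means a weaker inhibitor, a lower number a stronger inhibitor. Compound 1 gives 18000 nM and compound 2 gives 68000 nM. For compound 3 the assay reports only a limit, > 100000 nM. That value sits at the limit of > 100000 nM in this assay, at which 1 of the 3 values shown sits, so compound 3 stands at the weak end of what is known. For the measured compounds named here, the only measured step is an at least 5.5-fold higher number from compound 1 to compound 3 (0.74 log units; beyond the scatter). Compound 4 `CCOCn1cc(C#N)c2c(N)ncnc21` has not been measured; it differs from compound 3 by ethoxy in place of vinyl on a saturated chain carbon bound to an aromatic nitrogen. Going by the values given here, no measured step covers this change. Compound 2 carries the same ethoxymethyl chain, with a thioamide in place of the nitrile, and gives 68000 nM. The expected step is therefore an at least 1.2-fold lower number from compound 3 to compound 4 (0.09 log units; that floor lies within the scatter), back toward a measurable number. Compound 4 is estimated at 80000 nM, between 30000 nM and 250000 nM.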

Compound 4, half-maximal inhibitory concentration: > 100000 nM
Compound 4: no number, only a limit; the forecaster's own chance of this, stated with the estimate: 40%; middle value at least 1.2-fold (0.09 log units) from the limit.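

Ethoxymethyl on the aromatic nitrogen leaves the core of compound 1 no more active than allyl does as far as can be seen, and the step between compound 3 and compound 4 cannot be read because both give only a limit: the limit of > 100000 nM in this assay, at which 2 of the 4 values shown sit. In this assay ethoxymethyl in place of hydrogen gives an at least 5.5-fold higher number from compound 1 to compound 4 (0.74 log units; beyond the scatter) and so, like allyl, goes with a weaker result than hydrogen. Nitrile in place of the thioamide gives an at least 1.4-fold higher number from compound 2 to compound 4 (0.16 log units; that floor lies within the scatter) and so shows no clear effect of that swap.

As far as these compounds go, whether a methyl group or an amine-bearing chain on this nitrogen would keep the activity of compound 1 remains open. From the compounds shown here alone, how weak compound 3 and compound 4 really are also remains open.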